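Swapping the thiadiazole for a methylthiazole on the piperazine

A few compounds are considered here, and "the series" means these few. Any claim that something is new, unique, unknown or untested is made for them only; others in the source may bear on it.

Going by the values given here, compound 2 `COCc1nsc(N2CCN(C(=O)[C@@H]3CN[C@H](C(=O)N4CCCC4)C3)CC2)n1` gives 49 nM in an assay on a cell-free system (plasma) for inhibition of Dipeptidyl peptidase 4 (Rattus norvegicus), read by fluorescence (a higher number here means a weaker inhibitor, a lower number a stronger inhibitor), the lowest of the two numbers measured so far. Among the compounds with values here, its nearest neighbour is compound 1 `CCCc1nsc(N2CCN(C(=O)[C@@H]3CN[C@H](C(=O)N4CCCC4)C3)CC2)n1`, which gives 110 nM in this assay; the one measured step, a 2.2-fold lower number from compound 1 to compound 2 (0.35 log units; beyond the scatter), is modest in size. Compound 3 `Cc1ncc(N2CCN(C(=O)[C@@H]3CN[C@H](C(=O)N4CCCC4)C3)CC2)s1` has not yet been measured. It differs from compound 2 by 2-methyl-1,3-thiazol-5-yl in place of 3-(methoxymethyl)-1,2,4-thiadiazol-5-yl on an amine nitrogen in a ring. Within the data shown here, no measured step touches this part of the molecule: the single step concerns only the group on the saturated chain carbon, and it bears on the new change only in showing that a small alteration of the aromatic substituent moved the number by a modest amount. Compound 3 is therefore expected to give about 85 nM in this assay, with a range from 25 nM to 300 nM. The expected step, a 1.7-fold higher number from compound 2 to compound 3 (0.24 log units; within the scatter), may lie just beyond the scatter, towards a weaker inhibitor.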

Compound 3, half-maximal inhibitory concentration: 340 nM
For compound 3 the middle estimate is 4.0-fold (0.60 log units) below the measured one, outside the stated range (above it).
By their numbers in this assay, from the lowest: compound 2; then compound 1; then compound 3.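

Unlike the earlier step, which touched only the chain on the aromatic ring, this change replaces the ring itself on an amine nitrogen in a ring, and in this assay 2-methyl-1,3-thiazol-5-yl in place of 3-(methoxymethyl)-1,2,4-thiadiazol-5-yl gives a 6.9-fold higher number from compound 2 to compound 3 (0.84 log units; beyond the scatter). Set against 3-propyl-1,2,4-thiadiazol-5-yl, the same group gives a 3.1-fold higher number from compound 1 to compound 3 (0.49 log units; beyond the scatter), so both thiadiazoles shown, with either chain, stand on the stronger side of compound 3, and this position responds to the choice of ring at least as much as to the chain. Nothing available here accounts for this difference.

Compound 3 changes the ring and its substituent together, so the compounds shown do not separate the two, and a 2-(methoxymethyl)-1,3-thiazol-5-yl group would bear directly on that. On these data alone, how a six-membered aromatic ring such as pyridine would read at this position also stays open.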